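Pyridinyloxy variation on the piperidine amide series

The source may hold more compounds than are shown below. What is called first, only, known or untested is meant among the compounds shown, and "the series" means these compounds.

Of the compounds shown here, two carry a number so far. Compound 1 `CCOC(=O)c1ccccc1C(=O)N1C[C@H](Oc2cc(C#N)ccn2)CC[C@H]1C` holds an ester on the benzoyl part and a cyano-pyridinyloxy group; in a functional assay on CHO-K1 cells for antagonist activity at Orexin/Hypocretin receptor type 1 (Homo sapiens), read by FLIPR and calcium flux (on this read-out higher numbers stand for weaker inhibition and lower numbers for stronger inhibition), compound 1 gives 7100 nM. Compound 2 `CCc1ccnc(O[C@@H]2CC[C@@H](C)N(C(=O)c3ccccc3-n3nccn3)C2)c1` instead carries the triazolyl-benzoyl part together with the 4-ethylpyridin-2-yl ether; in this assay compound 2 gives 310 nM, the lowest of the two numbers and well apart from compound 1, beyond the scatter. Within the data shown here, no single-point step between the two is defined, since they differ in more than one place, so only the two values themselves can be compared.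

Compound 3 `Cc1cccc(O[C@@H]2CC[C@@H](C)N(C(=O)c3ccccc3-n3nccn3)C2)n1` keeps the shared core of compound 2 and changes only the ether: 6-methylpyridin-2-yl in place of 4-ethylpyridin-2-yl on an oxygen on a saturated carbon. Among the measured compounds shown here, no measured step of this kind exists, so the expectation leans on compound 2 alone at 310 nM. A small move is expected, most likely toward a somewhat higher number, possibly none beyond the scatter; the expected step is a 1.6-fold higher number from compound 2 to compound 3 (0.21 log units; within the scatter). For compound 3 the estimate in this assay is 500 nM, with a range from 150 nM to 2000 nM.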

Compound 3, half-maximal inhibitory concentration: 745 nM
For compound 3 the middle estimate is 1.5-fold (0.17 log units) below the measured one; measured number inside the range.
By their numbers in this assay, from the lowest: compound 2; then compound 3; then compound 1.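

On an oxygen on a saturated carbon, the ether group is not a silent variation: in this assay, 6-methylpyridin-2-yl in place of 4-ethylpyridin-2-yl gives a 2.4-fold higher number from compound 2 to compound 3 (0.38 log units; beyond the scatter), a modest step that lies beyond the scatter. Among these compounds, this is the first reading with the triazolyl-benzoyl part held fixed, so the number is seen to respond to the pyridinyl group alone, which the pair of compound 1 and compound 2, differing in more than one place, could not show. No measurement at hand bears on why the number moves with this change.

The names of the two groups differ both in the chain, ethyl against methyl, and in its numbered place on the pyridine, and this single pair cannot separate the two changes. Also open, from the compounds shown here alone, is how the number would respond to a plain pyridin-2-yl without any chain, or to a methoxy group, a chlorine or a longer chain such as propyl on the pyridine, with the rest of the shared core kept as it is in compound 2.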